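From benzoyl to benzyl on the amine nitrogen

The source may report more compounds than this note shows. Statements on the series, on what has been measured and on what is new or still open speak of the compounds shown alone.

In a functional assay for inhibition, with Rattus norvegicus as the target (a higher number here means that more compound is needed for the effect, a lower number that less compound is needed), compound 1 `CSCC[C@H](NC(=O)c1ccc(CNCCC2CCCCC2)cc1-c1ccccc1C)C(=O)O` gives 200 nM. Compound 2 `CSCC[C@H](NC(=O)c1ccc(CN(CCC2CCCCC2)C(=O)OC(C)(C)C)cc1-c1ccccc1C)C(=O)O` gives 160 nM, and the move on the amine nitrogen, a 1.3-fold lower number from compound 1 to compound 2 (0.10 log units; within the scatter), changes little. Compound 3 `CSCC[C@H](NC(=O)c1ccc(CN(CCC2CCCCC2)C(=O)c2ccccc2)cc1-c1ccccc1C)C(=O)O` returns only a limit, > 1000 nM, and no number.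

Compound 4 `CSCC[C@H](NC(=O)c1ccc(CN(CCC2CCCCC2)Cc2ccccc2)cc1-c1ccccc1C)C(=O)O` alters compound 3 at that same nitrogen: benzyl in place of benzoyl on an amine nitrogen. Within the data shown here, no measured step shows benzyl itself, so the estimate rests on three neighbouring steps. Benzoyl gave an at least 5.0-fold higher number from compound 1 to compound 3 (0.69 log units; beyond the scatter), and replacing tert-butoxy with phenyl on the carbonyl carbon gave an at least 6.2-fold higher number from compound 2 to compound 3 (0.79 log units; beyond the scatter). Yet compound 2 shows, with a 1.3-fold lower number from compound 1 to compound 2 (0.10 log units; within the scatter), that a substituent on this nitrogen need not raise the number. Compound 4 keeps the phenyl ring but loses the carbonyl, so a partial return towards compound 1 is expected, though not a certain one. The expected change is an at least 2.8-fold lower number from compound 3 to compound 4 (0.45 log units; beyond the scatter). For compound 4 the estimated value is 350 nM, within an expected range of 100 nM to 1200 nM.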

Compound 4, half-maximal effective concentration: > 1000 nM
Compound 4 was reported as a limit (the forecaster's own chance of this, stated with the estimate: 25%); at least 2.8-fold (0.45 log units) between middle value and limit.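

In this assay, compound 4 is also reported only as a limit, > 1000 nM. Benzyl on the amine nitrogen gives an at least 5.0-fold higher number from compound 1 to compound 4 (0.69 log units; beyond the scatter) and an at least 6.2-fold higher number from compound 2 to compound 4 (0.79 log units; beyond the scatter), so among these compounds a phenyl ring carried on this nitrogen, in compound 3 and compound 4, goes with the higher number whether or not a carbonyl is present. The step from benzoyl to benzyl itself cannot be read because both compounds stand at a limit: the limit of > 1000 nM in this assay, at which 2 of the 4 values shown sit.

As far as these compounds go, how far compound 3 and compound 4 lie beyond that limit remains open, and so does their order. Also open, from the compounds shown here alone, is whether methyl on this nitrogen, or a carboxylic acid on the phenyl ring of the benzyl group, would bring the number back towards that of compound 1.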